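Fluoro for chloro: from compound 3 to compound 4

The source may report more compounds than this note shows. Statements on the series, on what has been measured and on what is new or still open speak of the compounds shown alone.

Compound 1 `COc1cc2c(cc1N1C[C@@H](C)N(C)[C@@H](C)C1)N(C(=O)c1ccc(-c3cccc(C)n3)c3ccccc13)CC2` gives 0.3 in an assay on isolated protein with 5-hydroxytryptamine receptor 1B (Homo sapiens) as the target; on this read-out lower numbers stand for smaller maximal responses and higher numbers for larger maximal responses. Compound 2 `COc1cc2c(cc1N1CCN(C)CC1)N(C(=O)Nc1cccc(Cl)c1Cl)CC2` gives 0.6 in this assay. Compound 3 `COc1cc2c(cc1N1C[C@@H](C)N(C)[C@@H](C)C1)N(C(=O)Nc1cccc(Cl)c1Cl)CC2` gives 0.1 in this assay, the lowest of the three numbers, beyond the scatter below compound 1 and further below compound 2. Among the measured compounds shown here, the single measured step is a number 0.50 lower from compound 2 to compound 3 (beyond the scatter), and it concerns a different part of the structure. Compound 4 `COc1cc2c(cc1N1C[C@@H](C)N(C)[C@@H](C)C1)N(C(=O)Nc1cccc(Cl)c1F)CC2` differs from compound 3 by fluoro in place of chloro on an aromatic carbon. For the measured compounds named here, no measured step alters this group, so nothing in the data bears on the swap, and the expectation is a step within the scatter, a number 0.050 higher from compound 3 to compound 4 (within the scatter), in no set direction. Compound 4 is therefore estimated at 0.15 in this assay, within 0 to 0.35.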

Compound 4, intrinsic activity: the largest response reached, as a fraction of the reference agonist's: 0.1
Estimate against measurement, compound 4: 0.050 above; the range from low to high includes it.
By their numbers in this assay, from the lowest: compounds 3 and 4 (each within the scatter of the next); then compound 1; then compound 2.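

In this assay, among the compounds shown here, the swap from 2,3-dichlorophenyl to 3-chloro-2-fluorophenyl gives no change at the digits printed from compound 3 to compound 4 (within the scatter) and is the first measured step at this position. On this read-out, fluoro and chloro on this aromatic carbon cannot be told apart. Nothing measured here speaks to why the two halogens read alike.

Going by these compounds, it remains open whether an amine or a methoxy group on this carbon would read the same. Also open, on these data alone, is whether, with compound 2 at 0.6 and its 4-methylpiperazin-1-yl group, the same swap would read alike.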